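Benzyl in Place of Isopropyl on a Sulfur

A few compounds are considered here, and "the series" means these few. Any claim that something is new, unique, unknown or untested is made for them only; others in the source may bear on it.

In an ADME assay on brain (Mus musculus) for metabolic stability, read by HPLC (on this read-out lower numbers stand for a shorter-lived compound and higher numbers for a longer-lived compound), compound 1 `CCSS/C(CCOC(=O)[C@@H](C)c1ccc2cc(OC)ccc2c1)=C(/C)N(C=O)CC(=O)OC[C@H]1O[C@H](O)[C@H](O)[C@@H](O)[C@@H]1O` gives 0.243 h, and compound 2 `COc1ccc2cc([C@H](C)C(=O)OCC/C(SSC(C)C)=C(\C)N(C=O)CC(=O)OC[C@H]3O[C@H](O)[C@H](O)[C@@H](O)[C@@H]3O)ccc2c1` gives 0.343 h. Among the compounds with values here, these two values lie within the usual scatter of each other, so compound 2 stands level with compound 1 on the numbers so far. The next structure, compound 3 `COc1ccc2cc([C@H](C)C(=O)OCC/C(SSCc3ccccc3)=C(\C)N(C=O)CC(=O)OC[C@H]3O[C@H](O)[C@H](O)[C@@H](O)[C@@H]3O)ccc2c1`, changes one group of compound 2: benzyl in place of isopropyl on a sulfur. Within the data shown here, only one measured step bears on this change, a 1.4-fold higher number from compound 1 to compound 2 (0.15 log units; within the scatter), which is a methyl in place of hydrogen on a saturated chain carbon bound to a saturated chain carbon and a sulfur. Among the measured compounds shown here, that step stays within the scatter, and no measured compound carries a benzyl group, so the guide is weak. The expected size is therefore nothing beyond the scatter, an estimated 1.0-fold lower number from compound 2 to compound 3 (0.02 log units; within the scatter). For compound 3 the estimated half-life is 0.33 h, with an expected range from 0.16 h to 0.68 h.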

Compound 3, half-life in the brain assay: 0.312 h
Compound 3: the middle estimate sits 1.1-fold (0.02 log units) above what was measured; low and high end bracket the measured number.
By their numbers in the brain assay, from the lowest: compounds 1, 3 and 2 (each within the scatter of the next).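

In the brain assay, compound 1 gives 0.243 h, compound 2 gives 0.343 h and compound 3 gives 0.312 h; the swap from isopropyl to benzyl on this sulfur brings in a six-membered aromatic ring, yet it gives a 1.1-fold lower number from compound 2 to compound 3 (0.04 log units; within the scatter), and the comparison with the smaller group on compound 1 gives a 1.3-fold higher number from compound 1 to compound 3 (0.11 log units; within the scatter), so across these three compounds this position takes a ring with no shift beyond the scatter. In a physicochemical assay for pharmacokinetics, read by HPLC, in phosphate buffer, at pH 7.4 (a higher number here means that the compound lasts longer, a lower number that the compound disappears faster), compound 2 gives 51 h and compound 3 gives 30.1 h, and the same swap gives a 1.7-fold lower number from compound 2 to compound 3 (0.23 log units; within the scatter), so the physicochemical assay does not separate the two groups either. Nothing available explains these results.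

On these data alone, whether an amine or a carboxylic acid on the benzyl group, or a longer chain on the sulfur, would move the half-life beyond the scatter remains open. As far as these compounds go, all three compounds also keep this sulfur bound to a second sulfur, so the effect of replacing that link is unknown.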